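Changing the Aryl Group on an Inactive Nucleoside Series

The compounds below may be only part of what the source reports. "The series", "measured", "known", "first", "only" and "open" are said of these compounds alone.

Compound 1 `Cc1ncnc2c1c(-c1cccs1)cn2[C@@H]1O[C@H](CO)[C@@H](O)[C@H]1O` gives in a functional assay on HeLa S3 cells (Homo sapiens) for antiproliferative activity, read by XTT assay, with a stated time of 72 h (a lower number here means a stronger inhibitor, a higher number a weaker inhibitor), only the limit > 15000 nM.
Compound 2 `CNc1ncnc2c1c(-c1ccoc1)cn2[C@@H]1O[C@H](CO)[C@@H](O)[C@H]1O` gives in this assay only the limit > 20000 nM.
Compound 3 `Cc1ncnc2c1c(-c1cc3ccccc3o1)cn2[C@@H]1O[C@H](CO)[C@@H](O)[C@H]1O` gives in this assay only the limit > 20000 nM.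

Compound 3 therefore has no measured number, only a limit, and the same holds for every other compound tested, so its standing among them cannot be read. Going by the values given here, the one single-point step, a step that the two limits leave unreadable from compound 1 to compound 3, is unreadable because the limit of > 15000 nM in this assay, at which 1 of the 3 values shown sits, and the limit of > 20000 nM in this assay, at which 2 of the 3 values shown sit, cap both ends. The move to compound 4 `Cc1ncnc2c1c(-c1ccoc1)cn2[C@@H]1O[C@H](CO)[C@@H](O)[C@H]1O` is furan-3-yl in place of 1-benzofuran-2-yl on an aromatic carbon. Among the compounds with values here, no measured step bears readably on this change. Within the data shown here, the only hint is compound 2, which also carries furan-3-yl and sits at a limit, as already given. Compound 4 is thus expected to remain at a limit, with a number no higher from compound 3 to compound 4 (the limit leaves the size open) as the step expected. The estimate for compound 4 in this assay is 20000 nM, with a range from 10000 nM to 40000 nM.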

Compound 4, half-maximal inhibitory concentration: > 20000 nM
Compound 4 was reported as a limit; the forecaster's own chance of this, stated with the estimate: 85%; the middle value lies on the limit itself.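

In this assay, going by these compounds alone, compound 4 gives only a limit, > 20000 nM, so no step linking it to compound 1, compound 2 or compound 3 can be read: the limit of > 20000 nM in this assay, at which 3 of the 4 values shown sit. The compounds shown leave open whether any of these four differs from the others in real potency.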